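Extending the amide side chain of a weak amine oxidase inhibitor

The compounds below may be only part of what the source reports. "The series", "measured", "known", "first", "only" and "open" are said of these compounds alone.

Measured compounds:
- compound 1, `CCOC(=O)c1ccc(NC(=O)C(=O)c2ccccc2NC(C)=O)cc1`: 990000 nM
- compound 2, `COC(=O)[C@H](CC(C)C)NC(=O)C(=O)c1ccccc1NC(C)=O`: 480000 nM
- compound 3, `COC(=O)[C@@H](NC(=O)c1ccc(NC(=O)C(=O)c2ccccc2NC(C)=O)cc1)C(C)C`: 430000 nM

All three share a core bearing an acetylamino group and an oxo-amide link, and all were tested in an assay on mitochondria from brain for inhibition of Amine oxidase [flavin-containing] B (Bos taurus); on this read-out lower numbers stand for stronger inhibition and higher numbers for weaker inhibition. Compound 3 gives the lowest of the three numbers. Its gap to compound 2 lies within the scatter, so the two cannot be ranked. Going by the values given here, the one recorded step is a 2.3-fold lower number from compound 1 to compound 3 (0.36 log units; beyond the scatter), a modest step.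

Compound 4, `COC(=O)CCCCCNC(=O)c1ccc(NC(=O)C(=O)c2ccccc2NC(C)=O)cc1`, has not been measured. It differs from compound 3 by 5-(methoxycarbonyl)pentyl in place of 1-(methoxycarbonyl)-2-methylpropyl on an amide-type nitrogen. Among the compounds with values here, no measured pair shows this kind of change; the only step recorded, that from compound 1 to compound 3, concerns a different position. Compounds 2 and 3 suggest that two quite different groups on this part of the molecule give numbers within the scatter of each other, which points to no step beyond the scatter.

Compound 4 is therefore expected to give about 420000 nM, within 150000 nM to 1200000 nM. The estimated step of a 1.0-fold lower number from compound 3 to compound 4 (0.01 log units; within the scatter) is expected to stay within the scatter.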

Compound 4, half-maximal inhibitory concentration: 780000 nM
The estimate for compound 4 lay 1.9-fold (0.27 log units) below the measured number, and the stated range covers the measured number.
By their numbers in this assay, from the lowest: compounds 3, 2, 4 and 1 (each within the scatter of the next, the first and the last beyond it).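

In this assay, 5-(methoxycarbonyl)pentyl in place of 1-(methoxycarbonyl)-2-methylpropyl on an amide-type nitrogen gives a 1.8-fold higher number from compound 3 to compound 4 (0.26 log units; within the scatter), so this swap, which also removes the defined stereocentre, cannot be told apart from no change. Measured against the ethoxy group of compound 1, the new side chain gives a 1.3-fold lower number from compound 1 to compound 4 (0.10 log units; within the scatter), so compound 4 does not repeat the step beyond the scatter that compound 3 showed from that same starting point. No measurement shown here offers an explanation for these numbers.

From the compounds shown here alone, whether a carboxylic acid in place of the methoxycarbonyl group would shift the number beyond the scatter remains open. The same holds for an amine or a longer chain on this amide-type nitrogen.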